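Hydroxy to methyl on the aromatic ring: cytotoxicity notes

The source may report more compounds than this note shows. Statements on the series, on what has been measured and on what is new or still open speak of the compounds shown alone.

Measured so far in a functional assay on PC-3 cells (Homo sapiens) for cytotoxicity; on this read-out higher numbers stand for an effect only at larger amounts of compound and lower numbers for an effect already at smaller amounts
- compound 1 `COC1=C(C)C(=O)/C(=C(O)/C=C/c2cccc(OC)c2)C(=O)C1(C)C` gives 14.3 ug/mL
- compound 2 `COC1=C(C)C(=O)/C(=C(O)/C=C/c2ccc(O)cc2)C(=O)C1(C)C` gives > 20 ug/mL as a limit, not a number

Compound 2 stands only at a limit (the limit of > 20 ug/mL in this assay, at which 1 of the 2 values shown sits). Compound 3 `COC1=C(C)C(=O)/C(=C(O)/C=C/c2ccc(C)cc2)C(=O)C1(C)C` has methyl in place of hydroxy on an aromatic carbon, para to a large group (methyl in place of hydroxy on an aromatic carbon). Going by the values given here, the one measured step nearby is an at least 1.3-fold higher number from compound 1 to compound 2 (0.14 log units; that floor lies within the scatter) and it gives only weak guidance on size. It does not involve this exact exchange. Compound 1 also lacks the hydroxy and gives 14.3 ug/mL as a real number in this assay, so a reading near it is the working expectation. The expected change is an at least 1.4-fold lower number from compound 2 to compound 3 (0.15 log units; that floor lies within the scatter) and is estimated as modest, toward a lower number, with a limit reading still possible. Compound 3 is estimated at 14 ug/mL in this assay, with 7 ug/mL to 20 ug/mL as the expected range.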

Compound 3, concentration for half-maximal effect: 8.2 ug/mL
Compound 3: middle estimate off by 1.7-fold (0.23 log units), on the high side; low and high end bracket the measured number.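

In this assay, going by these compounds alone, methyl in place of hydroxy on an aromatic carbon, para to a large group, gives the first step that clears the scatter: an at least 2.4-fold lower number from compound 2 to compound 3 (0.38 log units; beyond the scatter). Compound 2 stands only at a limit, not a number, and the size of that step is therefore only a floor: the limit of > 20 ug/mL in this assay, at which 1 of the 3 values shown sits. 4-Methylphenyl in place of 3-methoxyphenyl gives a 1.7-fold lower number from compound 1 to compound 3 (0.24 log units; within the scatter), so these two groups are not told apart on this read-out.

Open, as far as these compounds go, is how an amine, a carboxylic acid or a longer chain such as propyl on the same aromatic carbon would read, and whether an unsubstituted phenyl would read closer to the hydroxy or the methyl compound. From the compounds shown here alone, whether the same reading holds outside this assay also stays open.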